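This account rests on a few compounds, and the source may have more. Where it says the series, first, only, none or still open, it means among the compounds named here.

Measured so far in a functional assay on MDA-MB-468 cells (Homo sapiens) for cytotoxicity, read by MTT assay, with a stated time of 48 h; a higher number here means a weaker inhibitor, a lower number a stronger inhibitor:
- compound 1, `COc1cccc(Nc2ncc3c(n2)NCC(=O)N3)c1` — > 100000 nM, a limit of the assay
- compound 2, `CN1CC(=O)Nc2cnc(Nc3ccccc3)nc21` — > 100000 nM, a limit of the assay

Compound 2 sits at the limit of this assay, with no number below it. The same holds for compound 1, whose value is also a limit. Among the measured compounds shown here, both values shown in this assay are therefore limits (the limit of > 100000 nM in this assay, at which 2 of the 2 values shown sit), and nothing so far gives a numerical anchor for where a true half-maximal inhibitory concentration might lie.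

Compound 3, `COc1cccc(Nc2ncc3c(n2)N(C)CC(=O)N3)c1`, has not yet been measured in this assay. It differs from compound 2 by methoxy in place of hydrogen on an aromatic carbon, on an aromatic carbon of a six-membered aromatic ring of carbon only, meta to a large group. For the measured compounds named here, no step between two measured compounds is available to calibrate this change. Since compound 1 carries the same methoxy group and also returns a limit, the expectation is that the step from compound 2 to compound 3 a step that the limit leaves unreadable from compound 2 to compound 3 brings no change beyond the scatter and that compound 3 most likely returns a limit again. Compound 3 is estimated at 150000 nM, in the range 40000 nM to 600000 nM.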

Compound 3, half-maximal inhibitory concentration: > 100000 nM
Compound 3: a limit, no number; the forecaster's own chance of this, stated with the estimate: 85%; the middle value does not contradict the limit.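

In this assay compound 3 gives > 100000 nM, a limit and not a number. Among the compounds shown here, no step among compound 1, compound 2 and compound 3 can be read, because all three sit at the same limit: the limit of > 100000 nM in this assay, at which 3 of the 3 values shown sit. The compounds shown leave open whether the methoxy group or the methyl on the ring nitrogen changes the half-maximal inhibitory concentration at all.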